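The source may report more compounds than this note shows. Statements on the series, on what has been measured and on what is new or still open speak of the compounds shown alone.

Measured in a functional assay on MCF7 cells (Homo sapiens) for inhibition, read by MTT assay, with a stated time of 48 h; on this read-out lower numbers stand for stronger inhibition of growth and higher numbers for weaker inhibition of growth:
compound 1 `COc1ccc2c(c1)c(C1CC(c3ccccc3)=NN1C(=O)c1ccc(OC)nc1)cn2C`: 990 nM
compound 2 `COc1cccc(C2=NN(C(=O)c3ccc(C)nc3)C(c3cn(C)c4ccc(OC)cc34)C2)c1`: 90 nM

Of these two, compound 2 has the lower number, and its gap to compound 1 lies beyond the usual scatter of this assay. Compound 3 `COc1cccc(C2=NN(C(=O)c3ccc(OC)nc3)C(c3cn(C)c4ccc(OC)cc34)C2)c1` has not yet been measured. It departs from compound 2 at a single place, with methoxy in place of methyl on an aromatic carbon, turning 6-methylpyridin-3-yl into 6-methoxypyridin-3-yl: methoxy in place of methyl on an aromatic carbon. Among the measured compounds shown here, no measured pair isolates this change, so the expectation rests on thin evidence. Compound 1 also carries the 6-methoxypyridin-3-yl group and gives 990 nM, which points towards weaker inhibition of growth. The expected change is modest and upward, a 2.0-fold higher number from compound 2 to compound 3 (0.30 log units; within the scatter), and it may not clear the scatter. Compound 3 is estimated at 180 nM, within an expected range of 50 nM to 650 nM.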

Compound 3, concentration for 50% growth inhibition: 130 nM
The estimate for compound 3 lay 1.4-fold (0.14 log units) above the measured number; measured number inside the range.
By their numbers in this assay, from the lowest: compounds 2 and 3 (each within the scatter of the next); then compound 1.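

In this assay, methoxy in place of methyl on the pyridine ring, next to the ring nitrogen, gives a 1.4-fold higher number from compound 2 to compound 3 (0.16 log units; within the scatter), so the two groups cannot be told apart at this place. The high number of compound 1 therefore does not follow the 6-methoxypyridin-3-yl group, which compound 1 and compound 3 share: the further methoxy that compound 3 carries elsewhere in the molecule gives a 7.6-fold lower number from compound 1 to compound 3 (0.88 log units; beyond the scatter), a step beyond the scatter. Nothing available here offers an explanation for either step.

The compounds shown leave open how an amine or a longer chain such as ethoxy would read at the pyridine position. They also leave open whether the step from hydrogen to methoxy keeps its size when the pyridine carries methyl instead of methoxy.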